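Cytotoxicity of Three Related Esters and an Unmeasured Fourth

A few compounds are considered here, and "the series" means these few. Any claim that something is new, unique, unknown or untested is made for them only; others in the source may bear on it.

Compound 1 `CCOC(=O)c1c(-c2cccc(OC(F)(F)F)c2)[nH]c2cc(OC)ccc2c1=O`, compound 2 `CCOC(=O)c1c(-c2cccc(Cl)c2)[nH]c2cc(OC)ccc2c1=O` and compound 3 `CCOC(=O)c1c(-c2cccc(OC(F)(F)F)c2)[nH]c2cc(C(F)(F)F)ccc2c1=O` were tested in an ADME assay on Raji cells (Homo sapiens) for cytotoxicity, read by luminescence, with a stated time of 72 h; a lower number here means that less compound is needed, a higher number that more compound is needed for the effect. In this assay compound 1 reaches only a limit, > 21500 nM. Compound 2 likewise gives only a limit, > 21500 nM. For compound 3 the result is again a limit, > 21500 nM. The change from compound 1 to compound 2 is chloro in place of trifluoromethoxy on an aromatic carbon, and it produces a step that the two limits leave unreadable from compound 1 to compound 2. Compound 4 `CCOC(=O)c1c(-c2cccc(Cl)c2)[nH]c2cc(C(F)(F)F)ccc2c1=O` has not yet been measured; it differs from compound 3 by chloro in place of trifluoromethoxy on an aromatic carbon, the same change at the same place. The two cores differ by trifluoromethyl in place of methoxy on an aromatic carbon, a change that from compound 1 to compound 3 gives a step that the two limits leave unreadable from compound 1 to compound 3. The step from compound 3 to compound 4 is expected to be a step that the limit leaves unreadable from compound 3 to compound 4, an expectation resting on (the limit of > 21500 nM in this assay, at which 3 of the 3 values shown sit), because all three measured values sit there and no size could be read from them. Compound 4 is therefore estimated at 40000 nM, within a range from 15000 nM to 150000 nM, most likely again only a limit.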

Compound 4, half-maximal effective concentration: > 21500 nM
Compound 4: no number, only a limit (the forecaster's own chance of this, stated with the estimate: 85%); the middle value lies beyond the limit too.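

In this assay compound 4 again gives only a limit, > 21500 nM, and the steps to it from compound 2 and compound 3 cannot be read. All four compounds stand alike: the limit of > 21500 nM in this assay, at which 4 of the 4 values shown sit.

The compounds shown leave open whether chloro in place of trifluoromethoxy, or trifluoromethyl in place of methoxy, changes the value in this assay at all, and by how much.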